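Cyclopentyl for hydroxyisopropyl on the shared core

This account rests on a few compounds, and the source may have more. Where it says the series, first, only, none or still open, it means among the compounds named here.

Measured so far:
compound 1 `COc1cc(-c2cnn3cc(OC)c(C(C)(C)O)nc23)ccn1`: 2700 nM
compound 2 `COc1cn2ncc(-c3ccnc(OC(C)C)c3)c2nc1-c1cnn(C)c1`: 2300 nM

Both numbers come from an assay on isolated protein for inhibition of activin receptor type-2A (Homo sapiens), read by 33P incorporation, with a stated time of 20 min, in the presence of a further agent that is not named here; a lower number here means a stronger inhibitor, a higher number a weaker inhibitor. Compound 1 gives 2700 nM, the higher of the two numbers. Compound 2 gives 2300 nM, which lies within the scatter of the number for compound 1, so the two are not separated.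

Compound 3 `COc1cc(-c2cnn3cc(OC)c(C4CCCC4)nc23)ccn1` differs from compound 1 in one place: cyclopentyl in place of 1-hydroxy-1-methylethyl on an aromatic carbon. Within the data shown here, no measured pair shows this change, so nothing fixes its size or direction. The step from compound 1 to compound 3 in this assay is expected to stay within the scatter, a 1.1-fold lower number from compound 1 to compound 3 (0.03 log units; within the scatter). Compound 3 is therefore estimated at 2500 nM, with a range from 800 nM to 8000 nM.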

Compound 3, half-maximal inhibitory concentration: 2900 nM
Beside the measured number, compound 3's estimate is 1.2-fold (0.06 log units) below it; the measured number falls inside the stated range.
By their numbers in this assay, from the lowest: compounds 2, 1 and 3 (each within the scatter of the next).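

In this assay, cyclopentyl in place of 1-hydroxy-1-methylethyl on this aromatic carbon gives a 1.1-fold higher number from compound 1 to compound 3 (0.03 log units; within the scatter), the first measured size for this change. The hydrogen-bond donor and acceptor of 1-hydroxy-1-methylethyl are absent from cyclopentyl, yet compound 1 and compound 3 are not separated. No measurement shown accounts for this result. On these data alone, whether an amine or a carboxylic acid on this carbon would separate from compound 1 remains open. So does whether the same change gives a similar step with other groups elsewhere on the shared core.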